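A few compounds are considered here, and "the series" means these few. Any claim that something is new, unique, unknown or untested is made for them only; others in the source may bear on it.

Measured so far in an assay on isolated protein for inhibition of protein deacetylase HDAC6 (Homo sapiens), read by fluorescence, with a stated time of 2 h; on this read-out lower numbers stand for stronger inhibition and higher numbers for weaker inhibition:
Compound 1, `CCCNNC(=O)c1ccc(CNC(=O)c2cnc3ccccc3c2)cc1`, gives > 10000 nM, which is a limit of the assay and not a number.
Compound 2, `CCCNNC(=O)c1ccc(CNC(=O)c2ccc3ccncc3c2)cc1`, gives > 10000 nM, again a limit rather than a number.
Compound 3, `CCCNNC(=O)c1ccc(CNC(=O)c2cc3ccccc3o2)cc1`, gives > 10000 nM, likewise a limit and not a measured number.

Going by the values given here, compound 3 therefore stands nowhere in particular among the three: all of them sit at the limit of > 10000 nM in this assay, at which 3 of the 3 values shown sit, so no ordering among them can be read from these results, and no step between any two of them has been quantified.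

Compound 4, `CCCNNC(=O)c1ccc(CNC(=O)c2cc3cc(O)ccc3o2)cc1`, is the next compound to be tested in this assay. It differs from compound 3 in a single place: hydroxy in place of hydrogen on an aromatic carbon, in words, hydroxy in place of hydrogen on an aromatic carbon, on a six-membered aromatic ring of carbon only that forms part of a fused system of two rings.

Among the compounds with values here, no measured step is available to guide the size of this change. With compound 3 at the limit of > 10000 nM in this assay, at which 3 of the 3 values shown sit, and no evidence pointing in either direction, the expected step from compound 3 to compound 4 is a step that the limit leaves unreadable from compound 3 to compound 4, that is, nothing beyond the scatter. Compound 4 is accordingly estimated at 15000 nM in this assay, with a range from 3000 nM to 60000 nM, and it is expected most likely to return only a limit again.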

Compound 4, half-maximal inhibitory concentration: > 10000 nM
Compound 4: a limit, no number; the forecaster's own chance of this, stated with the estimate: 80%; the middle value is on the limit's open side.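

No step can be read between compound 3 and compound 4, because the hydroxy in place of hydrogen on an aromatic carbon links two compounds that both sit at a limit and not at a number: the limit of > 10000 nM in this assay, at which 4 of the 4 values shown sit.

The compounds shown leave open how strongly any of them inhibits in this assay and whether that hydroxy changes it at all.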